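The source may hold more compounds than are shown below. What is called first, only, known or untested is meant among the compounds shown, and "the series" means these compounds.

So far, three compounds sharing one core have been measured in a physicochemical assay for lipophilicity, using the shake flask method, measured as octanol-water partition, at pH 7.4 (on this read-out lower numbers stand for lower lipophilicity and higher numbers for higher lipophilicity), and they span a wide range. Compound 1 (`CC(C)n1cc(-c2ccnc3[nH]c(C4CCNCC4)cc23)ccc1=O`) gives -0.2 as its reading. Compound 2 (`CNC(=O)CN1CCC(c2cc3c(-c4ccc(=O)n(C(C)C)c4)ccnc3[nH]2)CC1`) gives 2.2 as its reading. Compound 3 (`CC(C)Cn1cc(-c2ccnc3[nH]c(C4CCN(CC(=O)N(C)C)CC4)cc23)ccc1=O`) gives 2 as its reading, which is within the usual scatter of compound 2 and far beyond the scatter from compound 1.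

The next change leads from compound 3 to compound 4 (`CN(C)C(=O)CN1CCC(c2cc3c(-c4ccc(=O)n(CCC5CCOCC5)c4)ccnc3[nH]2)CC1`), which is still unmeasured. It is (oxan-4-yl)methyl in place of isopropyl on a saturated chain carbon bound to an aromatic nitrogen and it sits on a saturated chain carbon bound to an aromatic nitrogen.

Among the compounds with values here, the only measured step is a number 2.40 log units higher from compound 1 to compound 2 (beyond the scatter) with (methylcarbamoyl)methyl in place of hydrogen on an amine nitrogen in a ring. That large step lies at another place, so it offers only weak guidance here. Starting from compound 3 at 2 in this assay a slight upward step within the scatter is expected. The estimated step is a number 0.20 log units higher from compound 3 to compound 4 (within the scatter) and no more than that is expected. Compound 4 is estimated at 2.2 and expected to fall from 1.7 to 2.7 on this read-out.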

Compound 4, distribution coefficient: 1.5
For compound 4 the middle estimate is 0.70 log units above the measured one; the measured number lies below the stated range.
By their numbers in this assay, from the lowest: compound 1; then compound 4; then compounds 3 and 2 (each within the scatter of the next).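

The position on a saturated chain carbon bound to an aromatic nitrogen is not silent in this assay: (oxan-4-yl)methyl in place of isopropyl gives a number 0.50 log units lower from compound 3 to compound 4 (beyond the scatter) and is the first step shown at this place. The number goes down even though the entering group is the larger one, with 7 heavy atoms against 3, and it brings a six-membered non-aromatic ring holding one oxygen. No measurement available here accounts for this step.

This single change swaps chain size, ring and oxygen together, so the compounds shown cannot separate their contributions. A 2-cyclohexylethyl group, with carbon in place of the ring oxygen, or a chain ending in an amine at this place would help to tell them apart.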